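Pyridinyl ether series: from compound 2 to compound 3

The source may hold more compounds than are shown below. What is called first, only, known or untested is meant among the compounds shown, and "the series" means these compounds.

Measured so far:
compound 1 `O=C(Nc1ccc(F)cc1)C1(C(=O)Nc2ccc(Oc3ccnc4[nH]c(=O)[nH]c34)c(F)c2)CC1`: 240 nM
compound 2 `Nc1c(Oc2ccc(NC(=O)C3(C(=O)Nc4ccc(F)cc4)CC3)cc2F)ccnc1NC(=O)CCl`: < 10000 nM

In a functional assay on EBC-1 cells (Homo sapiens) for antiproliferative activity, read by sulforhodamine B assay, with a stated time of 72 h (on this read-out lower numbers stand for stronger inhibition and higher numbers for weaker inhibition), compound 1 gives 240 nM. For compound 2 the read-out is a limit only, < 10000 nM, as shown by the limit of < 10000 nM in this assay, at which 1 of the 2 values shown sits. The step that the limit leaves unreadable from compound 1 to compound 2 is therefore unreadable. Compound 3 `Nc1nccc(Oc2ccc(NC(=O)C3(C(=O)Nc4ccc(F)cc4)CC3)cc2F)c1NCC(=O)O` carries 2-amino-3-((carboxymethyl)amino)pyridin-4-yl in place of 3-amino-2-(((chloromethyl)carbonyl)amino)pyridin-4-yl on an oxygen on an aromatic ring. For the measured compounds named here, no measured step covers this change, and compound 2 itself has no number, so the expectation rests on the limit alone. Compound 3 is expected at 8000 nM, with a range from 1500 nM to 30000 nM. The expected step is a step that the limit leaves unreadable from compound 2 to compound 3, with a strong chance that this assay again reports only a limit.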

Compound 3, half-maximal inhibitory concentration: < 10000 nM
Compound 3 gave a limit, no number (the forecaster's own chance of this, stated with the estimate: 60%); the middle value is on the limit's open side.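

In this assay, for the compounds shown here, compound 3 gives only a limit, < 10000 nM, so no step from compound 1 or compound 2 to compound 3 can be read. On these data alone, the actual potencies of compound 2 and compound 3 remain open.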